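Amide variation on the chlorophenylpiperidine valinamide core

The source may report more compounds than this note shows. Statements on the series, on what has been measured and on what is new or still open speak of the compounds shown alone.

Measured so far in an assay on THP-1 cells for displacement of a labelled ligand from C-C chemokine receptor type 1 (Homo sapiens); a lower number here means a stronger inhibitor, a higher number a weaker inhibitor:
compound 1 `CC(C)[C@@H](NC(=O)c1cccc(F)c1)C(=O)N1CCC(c2ccc(Cl)cc2)CC1` gives 24 nM;
compound 2 `Cc1cccc(CCC(=O)N[C@@H](C(=O)N2CCC(c3ccc(Cl)cc3)CC2)C(C)C)c1` gives 22 nM.

Compound 2 has the lowest of the two numbers, but the step of a 1.1-fold lower number from compound 1 to compound 2 (0.04 log units; within the scatter) lies within the scatter, so compound 1 and compound 2 are indistinguishable on these data. The unmeasured compound 3 `CC(C)[C@@H](NC(=O)c1ccc(F)c(F)c1)C(=O)N1CCC(c2ccc(Cl)cc2)CC1` differs from compound 2 at the amide carbonyl: 3,4-difluorophenyl in place of 2-(3-methylphenyl)ethyl on a carbonyl carbon. Within the data shown here, the single measured step, from compound 1 to compound 2, swapped an aryl group for a longer arylalkyl chain on the same carbonyl without a shift beyond the scatter, which suggests this position tolerates change. Among the measured compounds shown here, no step compares the two fluorinated aryl amides directly. Compound 3 is therefore expected to stay close to the two measured values, a 1.1-fold higher number from compound 2 to compound 3 (0.06 log units; within the scatter), with an estimate of 25 nM and a range of 10 nM to 65 nM.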

Compound 3, half-maximal inhibitory concentration: 14 nM
Compound 3: the middle estimate sits 1.8-fold (0.25 log units) above what was measured, within the range that was stated.
By their numbers in this assay, from the lowest: compounds 3, 2 and 1 (each within the scatter of the next).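

Exchanging 2-(3-methylphenyl)ethyl for 3,4-difluorophenyl on the carbonyl carbon gives a 1.6-fold lower number from compound 2 to compound 3 (0.20 log units; within the scatter) in this assay, so a third group at this position also shows no shift beyond the scatter. The direct comparison of the two fluorinated aryl amides, fluoro in place of hydrogen on an aromatic carbon, gives a 1.7-fold lower number from compound 1 to compound 3 (0.23 log units; within the scatter), so the extra fluoro has no effect that can be separated from repeat variation. No available evidence bears on these results.

All three groups on this carbonyl contain a six-membered aromatic ring of carbon only, so an aliphatic amine, a carboxylic acid or a longer chain ending in that ring remains an open case. As far as these compounds go, whether the same tolerance holds on a changed core is also open.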